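One Carbon Longer on the Side Chain of Compound 1

A few compounds are considered here, and "the series" means these few. Any claim that something is new, unique, unknown or untested is made for them only; others in the source may bear on it.

Of the compounds shown here, three share a core and have been tested in a physicochemical assay for solubility, with a stated time of 18 h, at pH 7.4; on this read-out lower numbers stand for lower solubility and higher numbers for higher solubility. Compound 1, with the structure `CC(C)Cc1ccc2c(NCCCNCc3ccco3)ccnc2c1`, gives 4200 nM. Compound 2, with the structure `COc1ccc(F)cc1CNCCCNc1ccnc2cc(Cc3cc(C)cc(C)c3)ccc12`, gives 4200 nM, which at the digits shown is level with compound 1 and inside the usual scatter, so no order between the two can be read. Compound 3, with the structure `COc1cccc(CNCCCNc2ccnc3cc(Oc4ccc(Cl)cc4)ccc23)c1O`, gives 14500 nM, and its gap to compound 1 lies beyond the scatter, so compound 1 and compound 2 together hold the lowest of the three numbers and compound 3 sits apart from them. Within the data shown here, no pair of these three differs in only one place, so no single structural step has yet been measured.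

Compound 4, with the structure `CC(C)CCc1ccc2c(NCCCNCc3ccco3)ccnc2c1`, is not yet measured. It differs from compound 1 in one place: isobutyl in place of isopropyl on a saturated chain carbon bound to an aromatic carbon. Among the measured compounds shown here, with no measured step of this kind to lean on, the expectation rests on compound 1 alone, whose 4200 nM is the starting point. The estimated step of a 1.5-fold lower number from compound 1 to compound 4 (0.18 log units; within the scatter) is expected to be small and downward, not clearly beyond the scatter. Compound 4 is therefore expected to give about 2800 nM, within a range from 1100 nM to 7000 nM.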

Compound 4, solubility: 4200 nM
Estimate against measurement, compound 4: 1.5-fold (0.18 log units) below; the measured number falls inside the stated range.
By their numbers in this assay, from the lowest: compounds 1, 2 and 4 (each within the scatter of the next); then compound 3.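

Among these compounds, compounds 1 and 4 differ in one place only, which gives the first single structural step in this set. In this assay, isobutyl in place of isopropyl on a saturated chain carbon bound to an aromatic carbon gives no change at the digits printed from compound 1 to compound 4 (within the scatter), so at this place, adding one carbon to the group does not separate the two compounds on this read-out. Nothing available here explains this outcome.

This is one small change between two purely carbon groups, so it does not show whether the read-out would stay level with a much longer chain, such as octyl, or with a group of a different kind at the same place, such as an amine or a carboxylic acid. It also leaves open whether the same change would give the same result on a compound that differs elsewhere, since this step has been read only on the structure of compound 1.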